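The compounds below may be only part of what the source reports. "The series", "measured", "known", "first", "only" and "open" are said of these compounds alone.

Working notes on the series. In a functional assay on Fem-X cells (Homo sapiens) for cytotoxicity (a lower number here means a stronger inhibitor, a higher number a weaker inhibitor), compound 1 (`CC1=CCC[C@H]2[C@](C)(CC3=CC(=O)C(SC(C)(C)C)=CC3=O)[C@@H](C)CC[C@]12C`) gives 38000 nM. Compound 3 (`CC1=CCC[C@H]2[C@](C)(CC3=CC(=O)C=CC3=O)[C@@H](C)CC[C@]12C`), with hydrogen in place of (tert-butyl)sulfanyl, gives 23900 nM, and a 1.6-fold lower number from compound 1 to compound 3 (0.20 log units; within the scatter) leaves the two level within the scatter. Compound 2 (`CCCCCCCCSC1=CC(=O)C(C[C@]2(C)[C@@H](C)CC[C@]3(C)C(C)=CCC[C@@H]23)=CC1=O`) reads > 100000 nM, which is a limit of the assay and not a number. The octyl change is an at least 2.6-fold higher number from compound 1 to compound 2 (0.42 log units; beyond the scatter), and removing octylsulfanyl is an at least 4.1-fold lower number from compound 2 to compound 3 (0.62 log units; beyond the scatter).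

The next change is compound 4 (`CC1=CCC[C@H]2[C@](C)(CC3=CC(=O)C(Sc4ccccc4)=CC3=O)[C@@H](C)CC[C@]12C`), with phenyl in place of tert-butyl on a sulfur. Among the compounds with values here, only the steps on the group carried by sulfur bear on it. The octyl step moved the number beyond the scatter, but loss of the whole group in compound 3 did not, as a 1.6-fold lower number from compound 1 to compound 3 (0.20 log units; within the scatter) shows. Within the data shown here, with no phenyl example measured, only a small upward or downward move is expected, so the expected step, a 1.3-fold lower number from compound 1 to compound 4 (0.10 log units; within the scatter), is not expected to exceed the scatter. For compound 4 the estimated value is 30000 nM, with an expected range of 10000 nM to 90000 nM.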

Compound 4, half-maximal inhibitory concentration: 42500 nM
Compound 4: middle estimate off by 1.4-fold (0.15 log units), on the low side; low and high end bracket the measured number.
By their numbers in this assay, from the lowest: compounds 3, 1 and 4 (each within the scatter of the next). At a limit, above all of these: compound 2.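

In this assay, phenyl on the sulfur gives no separation from either tert-butyl, a 1.1-fold higher number from compound 1 to compound 4 (0.05 log units; within the scatter), or hydrogen in place of the whole phenylsulfanyl group, a 1.8-fold higher number from compound 3 to compound 4 (0.25 log units; within the scatter), so an aromatic ring on the sulfur joins compound 1 and compound 3 in one level group. Phenyl in place of octyl gives an at least 2.3-fold lower number from compound 2 to compound 4 (0.37 log units; beyond the scatter), which makes octyl the only group on the sulfur among those shown that separates from the rest, and the larger phenyl does not share that separation. Compound 2 reads > 100000 nM, which is a limit of the assay and not a number: the limit of > 100000 nM in this assay, at which 1 of the 4 values shown sits.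

As far as these compounds go, it stays open where between tert-butyl and octyl the separation begins, for instance with a butyl or hexyl chain on the sulfur. From the compounds shown here alone, it is also open whether an amine or a carboxylic acid carried on the sulfur group would leave the number level with compound 1.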